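Series notes: methoxy for fluoro, compound 3 to compound 4

The compounds below may be only part of what the source reports. "The series", "measured", "known", "first", "only" and "open" are said of these compounds alone.

Measured so far in a functional assay on NCI-H1975 cells (Homo sapiens) for inhibition, read by MTT assay, with a stated time of 72 h; a higher number here means a weaker inhibitor, a lower number a stronger inhibitor:
compound 1 `O=C(CSc1nc(Nc2ccccc2)c2ccccc2n1)Nc1cccc(F)c1`: 6790 nM
compound 2 `O=C(CSc1nc(Nc2ccccc2)c2ccccc2n1)Nc1ccc(C(F)(F)F)cc1`: 11700 nM
compound 3 `C=CC(=O)Nc1cccc(NC(=O)CSc2nc(Nc3cccc(F)c3)c3ccccc3n2)c1`: 2030 nM

Compound 3 gives the lowest number of the three in this assay. Its gap to compound 1 is beyond the scatter, and its gap to compound 2 is larger still, so compound 3 stands apart as the strongest inhibitor among the measured compounds.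

Compound 4 `C=CC(=O)Nc1cccc(NC(=O)CSc2nc(Nc3cccc(OC)c3)c3ccccc3n2)c1` differs from compound 3 in one place: methoxy in place of fluoro on an aromatic carbon. Going by the values given here, the only measured step within the set is a 1.7-fold higher number from compound 1 to compound 2 (0.24 log units; within the scatter); it concerns the aryl group on the amide-type nitrogen, not the (3-fluorophenyl)amino group where the new change sits, and it stays within the scatter. Among the compounds with values here, no measured step touches a substituent on the (3-fluorophenyl)amino ring, so there is no direct guide for the fluoro-to-methoxy exchange. Within the data shown here, the one step available suggests that a single substituent swap on an aryl ring moves the number little.

Compound 4 is therefore expected to show a 1.2-fold higher number from compound 3 to compound 4 (0.09 log units; within the scatter) in this assay, no step beyond the scatter. The estimate for compound 4 is 2500 nM, with a range from 1000 nM to 6500 nM.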

Compound 4, half-maximal inhibitory concentration: 7940 nM
Beside the measured number, compound 4's estimate is 3.2-fold (0.50 log units) below it; measured number outside the range, above it.
By their numbers in this assay, from the lowest: compound 3; then compounds 1, 4 and 2 (each within the scatter of the next).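

In this assay, methoxy in place of fluoro on this aromatic carbon gives a 3.9-fold higher number from compound 3 to compound 4 (0.59 log units; beyond the scatter), so the substituent on the (3-fluorophenyl)amino ring of compound 3 cannot be exchanged freely in this assay. Going by these compounds alone, this is the first measured change on that ring, and it shows that a single exchange on an aryl ring can move the number beyond the scatter; the earlier step, a 1.7-fold higher number from compound 1 to compound 2 (0.24 log units; within the scatter), on the aryl group on the amide-type nitrogen, stayed within it and so gave no such signal. No available measurement bears on why the methoxy compound gives the higher number.

Open, as far as these compounds go, is how other groups at this same aromatic carbon would compare, for example a chlorine atom, a hydroxyl group or an ethoxy group, and so whether the step is specific to methoxy or extends to other replacements of fluoro. Also open, from the compounds shown here alone, is whether the same exchange keeps its size when the aryl group on the amide-type nitrogen is different.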